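Series notes: compound 3 to compound 4

The source may hold more compounds than are shown below. What is called first, only, known or untested is meant among the compounds shown, and "the series" means these compounds.

Values in a toxicity assay on HeLa cells (Homo sapiens) for cytotoxicity, read by LDH release, with a stated time of 24 h; on this read-out lower numbers stand for higher toxicity in this test and higher numbers for lower toxicity in this test:
- Compound 1 `O=C(O)[C@H](CCn1c(-c2ccccc2)n[nH]c1=S)N(Cc1c[nH]cn1)Cc1c[nH]cn1` gives > 250000 nM, a limit of the assay.
- Compound 2 `Cc1[nH]cnc1CN(Cc1nc[nH]c1C)[C@@H](CCCn1c(-c2ccccc2)n[nH]c1=S)C(=O)O` gives 141000 nM.
- Compound 3 `Cc1[nH]cnc1CN(Cc1c[nH]cn1)[C@@H](CCCn1c(-c2ccccc2)n[nH]c1=S)C(=O)O` gives 105000 nM.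

Among the compounds with values here, compound 3 has only one neighbour with a numeric value, and the single measured step is a 1.3-fold lower number from compound 2 to compound 3 (0.13 log units; within the scatter). Compound 1 stands at the limit of > 250000 nM in this assay, at which 1 of the 3 values shown sits.

Compound 4 `O=C(O)[C@H](CCCn1c(-c2ccccc2)n[nH]c1=S)N(Cc1ccccn1)Cc1c[nH]cn1` differs from compound 3 in one group: pyridin-2-yl in place of 5-methyl-1H-imidazol-4-yl on a saturated chain carbon bound to an amine nitrogen. Within the data shown here, no measured step covers this exchange. The nearest evidence, a 1.3-fold lower number from compound 2 to compound 3 (0.13 log units; within the scatter), concerns a different change, so it gives only weak guidance. In this assay, no shift beyond the scatter is expected, and no direction is favoured. The expected step is a 1.0-fold higher number from compound 3 to compound 4 (0.02 log units; within the scatter). For compound 4 the estimate is 110000 nM, with an expected range of 50000 nM to 240000 nM.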

Compound 4, half-maximal cytotoxic concentration: 175000 nM
Beside the measured number, compound 4's estimate is 1.6-fold (0.20 log units) below it; measured number inside the range.
By their numbers in this assay, from the lowest: compounds 3, 2 and 4 (each within the scatter of the next). At a limit, above all of these: compound 1.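

In this assay, the exchange of (5-methyl-1H-imidazol-4-yl)methyl for (pyridin-2-yl)methyl stays within the scatter: a 1.7-fold higher number from compound 3 to compound 4 (0.22 log units; within the scatter). The earlier step concerned only a methyl on the ring, whereas this one replaces the whole ring, the five-membered aromatic ring with its hydrogen-bond donor giving way to a six-membered aromatic ring with none, and still brings no shift beyond the scatter. Compound 1 remains the only compound at a limit: the limit of > 250000 nM in this assay, at which 1 of the 4 values shown sits.

Still open, on these data alone, is what a benzyl group or a saturated piperidinylmethyl group would give at this place on the amine nitrogen. Also open, as far as these compounds go, is whether exchanging both arms on that nitrogen for (pyridin-2-yl)methyl would keep the number within the scatter.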